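A second chlorine on the benzyl sulfide of compound 1

The source may hold more compounds than are shown below. What is called first, only, known or untested is meant among the compounds shown, and "the series" means these compounds.

Compound 1 `Cc1cc(N2CC[C@@H](C)[C@@H](N(C)c3ncnc4[nH]ccc34)C2)n2nc(SCc3ccc(Cl)cc3)nc2n1`: 18400 nM
Compound 2 `Cc1cc(N2CC[C@@H](C)[C@@H](N(C)c3ncnc4[nH]ccc34)C2)n2nc(SCc3nc4ccccc4[nH]3)nc2n1`: > 100000 nM, a limit of the assay and not a number.
Compound 3 `Cc1ccc(CSc2nc3nc(C)cc(N4CC[C@@H](C)[C@@H](N(C)c5ncnc6[nH]ccc56)C4)n3n2)cc1`: 15200 nM

The three measured compounds share one core and differ only in the group on a saturated chain carbon bound to a sulfur. In a functional assay on HGC-27 cells (Homo sapiens) for inhibition, read by MTT assay, with a stated time of 72 h (on this read-out higher numbers stand for weaker inhibition and lower numbers for stronger inhibition), compound 1 gives 18400 nM. Compound 1 and compound 3 cannot be ordered, since a 1.2-fold lower number from compound 1 to compound 3 (0.08 log units; within the scatter). Compound 2 stands apart: an at least 5.4-fold higher number from compound 1 to compound 2 (0.73 log units; beyond the scatter), and the same holds in the other direction, an at least 6.5-fold lower number from compound 2 to compound 3 (0.81 log units; beyond the scatter). Compound 2 is the one that sits at the limit of > 100000 nM in this assay, at which 1 of the 3 values shown sits.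

Compound 4 `Cc1cc(N2CC[C@@H](C)[C@@H](N(C)c3ncnc4[nH]ccc34)C2)n2nc(SCc3cc(Cl)ccc3Cl)nc2n1` is not yet measured. It differs from compound 1 in one place: 2,5-dichlorophenyl in place of 4-chlorophenyl on a saturated chain carbon bound to a sulfur

The measured steps touch this change only loosely. The step from compound 1 to compound 3 swaps one small substituent on the same ring and stays within the scatter; the step from compound 1 to compound 2 replaces the whole ring and is at least modest. Adding a second chlorine keeps the ring, so no step beyond the scatter is expected: a 1.2-fold lower number from compound 1 to compound 4 (0.09 log units; within the scatter). Compound 4 is therefore estimated at 15000 nM, between 6000 nM and 40000 nM.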

Compound 4, half-maximal inhibitory concentration: 19200 nM
Compound 4: the middle estimate sits 1.3-fold (0.11 log units) below what was measured, and the stated range covers the measured number.
By their numbers in this assay, from the lowest: compounds 3, 1 and 4 (each within the scatter of the next). At a limit, above all of these: compound 2.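

In this assay, adding a second chlorine to the benzyl group gives no readable change at this position on the chain carbon bound to the sulfur (the step is a 1.0-fold higher number from compound 1 to compound 4 (0.02 log units; within the scatter)). The new compound also cannot be ordered against the methyl analogue (a 1.3-fold higher number from compound 3 to compound 4 (0.10 log units; within the scatter)), so compounds 1, 3 and 4 now form a group of three phenyl-bearing compounds whose numbers lie within the scatter, whether the ring carries 4-chloro, 4-methyl or 2,5-dichloro substitution. Compound 2, with its 1H-benzimidazol-2-yl group, goes against this flat picture (an at least 5.2-fold lower number from compound 2 to compound 4 (0.71 log units; beyond the scatter)), and its value is a limit of the assay and not a number: the limit of > 100000 nM in this assay, at which 1 of the 4 values shown sits.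

The compounds shown leave open whether the sharp separation belongs to the fused ring system of compound 2 or to its ring nitrogens, a question that a pyridine ring or a naphthyl group at the same place could address. They also leave open whether an amine or a carboxylic acid on the phenyl ring, or a longer chain between the sulfur and the ring, would shift the number where chlorine and methyl do not.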